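Replacing a Trifluoromethylbenzyl Arm with an Isopropylphenyl Arm

This account rests on a few compounds, and the source may have more. Where it says the series, first, only, none or still open, it means among the compounds named here.

Compound 1 `Cc1ccc(Nc2ncc(Cl)c(Nc3ccccc3C)n2)cc1`: > 100000 nM in a functional assay on MCF7 cells (Homo sapiens) for inhibition, read by CCK-8 assay, with a stated time of 48 h (a lower number here means a stronger inhibitor of growth, a higher number a weaker inhibitor of growth), a limit of the assay.
Compound 2 `Cc1ccccc1Nc1nc(Nc2ccccn2)ncc1Cl`: 31400 nM
Compound 3 `CN1CCN(c2ccc(Nc3ncc(Cl)c(NCc4ccc(C(F)(F)F)cc4)n3)nc2)CC1`: 28400 nM

Compound 3 stands lowest of the two numbers in this assay, yet its gap to compound 2 lies within the scatter. Compound 4 `CC(C)c1ccc(Nc2nc(Nc3ccc(N4CCN(C)CC4)cn3)ncc2Cl)cc1` carries 4-isopropylphenyl in place of 4-(trifluoromethyl)benzyl on a nitrogen on an aromatic ring. Among the measured compounds shown here, the one measured step, an at least 3.1-fold lower number from compound 1 to compound 2 (0.50 log units; beyond the scatter), concerns a different nitrogen and a different exchange, so it offers only a rough guide to how an aryl group on such a nitrogen is tolerated; one value of that pair is a limit (the limit of > 100000 nM in this assay, at which 1 of the 3 values shown sits). For the measured compounds named here, no step moves a benzyl against a phenyl. Compound 4 is therefore expected near compound 3, with a 1.3-fold lower number from compound 3 to compound 4 (0.11 log units; within the scatter) not beyond the scatter. Compound 4 is estimated at 22000 nM, between 6000 nM and 80000 nM.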

Compound 4, concentration for 50% growth inhibition: 1880 nM
For compound 4 the middle estimate is 12-fold (1.07 log units) above the measured one; the whole stated range lies above it.
By their numbers in this assay, from the lowest: compound 4; then compounds 3 and 2 (each within the scatter of the next). At a limit, above all of these: compound 1.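

In this assay, among the compounds shown here, the exchange on this nitrogen gives a 15-fold lower number from compound 3 to compound 4 (1.18 log units; beyond the scatter), the first measured change here, and it shows that growth inhibition responds strongly to the group held at this place. The exchange replaces the benzyl with a phenyl and the trifluoromethyl with an isopropyl in one step, so the two changes cannot be told apart. On these data alone, it remains open how 4-(trifluoromethyl)phenyl or 4-isopropylbenzyl would read on the same nitrogen. Nothing measured here gives a cause for the step.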